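Swapping the aryl group on the ring nitrogen of compound 2

A few compounds are considered here, and "the series" means these few. Any claim that something is new, unique, unknown or untested is made for them only; others in the source may bear on it.

Of the compounds shown here, two sharing one core have been measured in a functional assay on MCF7 cells (Homo sapiens) for cytotoxicity, read by MTT assay, with a stated time of 72 h; a lower number here means a stronger inhibitor, a higher number a weaker inhibitor. Compound 1 `CCCCCCCCNc1nc(SCc2ccc(C(F)(F)F)cc2)nc2ccccc12` carries an octyl chain on a nitrogen on an aromatic ring and gives 26100 nM. Compound 2 `O=[N+]([O-])c1ccc(Nc2nc(SCc3ccc(C(F)(F)F)cc3)nc3ccccc23)cc1` carries a 4-nitrophenyl group at the same nitrogen and gives 17900 nM. Of these two numbers compound 2 has the lower one, but the step of a 1.5-fold lower number from compound 1 to compound 2 (0.16 log units; within the scatter) sits within the scatter, so the two compounds cannot be told apart with confidence.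

Compound 3 `Fc1ccc(Nc2nc(SCc3ccc(C(F)(F)F)cc3)nc3ccccc23)cc1Cl` changes the same place once more: 3-chloro-4-fluorophenyl in place of 4-nitrophenyl on a nitrogen on an aromatic ring. Within the data shown here, no measured step swaps one aryl group for another, so the only guide is the step from compound 1 to compound 2, where a very different group at this nitrogen moved this assay by a 1.5-fold lower number from compound 1 to compound 2 (0.16 log units; within the scatter). That single step gives no reason to expect a change beyond the scatter in this assay from this exchange, in either direction.

The expected step for compound 3 is therefore a 1.1-fold lower number from compound 2 to compound 3 (0.05 log units; within the scatter). Compound 3 is estimated at 16000 nM, with a range from 5000 nM to 50000 nM.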

Compound 3, half-maximal inhibitory concentration: 23000 nM
Compound 3: middle estimate off by 1.4-fold (0.16 log units), on the low side, within the range that was stated.
By their numbers in this assay, from the lowest: compounds 2, 3 and 1 (each within the scatter of the next).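

In this assay, among these compounds, putting 3-chloro-4-fluorophenyl in place of 4-nitrophenyl gives a 1.3-fold higher number from compound 2 to compound 3 (0.11 log units; within the scatter) and is the first exchange of one aryl group for another at this nitrogen, so hydrogen-bond acceptors present on the group that leaves and absent from the group that enters go together with no readable change here. Against the octyl chain, the new compound gives a 1.1-fold lower number from compound 1 to compound 3 (0.05 log units; within the scatter) and so completes the set: the octyl chain and both aryl groups all lie within the scatter of one another, and none of the three can be ranked above another at this position. No independent evidence is available to explain why these compounds read alike.

On these data alone, whether a group of another type at this nitrogen, such as a benzyl group or a short chain ending in an amine or a carboxylic acid, would move the number beyond the scatter remains open. The compounds shown also share everything outside this one position, which leaves open how a change elsewhere on the shared core would read in this cell test.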